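Aryl swap on the triazole nitrogen of the spiro series

The source may report more compounds than this note shows. Statements on the series, on what has been measured and on what is new or still open speak of the compounds shown alone.

Compound 1 `CCc1ccccc1-n1nncc1CN1C(=O)C2(C(C#N)=C(N)Oc3c(N)cc4nc5ccccc5nc4c32)c2ccccc21` gives 22900 nM in an ADME assay on L02 cells (Homo sapiens) for antiproliferative activity, read by MTT assay, with a stated time of 48 h; on this read-out higher numbers stand for weaker inhibition and lower numbers for stronger inhibition.
Compound 2 `N#CC1=C(N)Oc2c(N)cc3nc4ccccc4nc3c2C12C(=O)N(Cc1cnnn1-c1ccc([N+](=O)[O-])cc1)c1ccccc12` gives only a limit in this assay, > 50000 nM.

Compound 2 sits at the limit of > 50000 nM in this assay, at which 1 of the 2 values shown sits, so no number is known for it. Compound 3 `Cc1ccc(-n2nncc2CN2C(=O)C3(C(C#N)=C(N)Oc4c(N)cc5nc6ccccc6nc5c43)c3ccccc32)cc1C` differs from compound 2 by 3,4-dimethylphenyl in place of 4-nitrophenyl on an aromatic nitrogen. Among the measured compounds shown here, the only measured step at this position is an at least 2.1-fold higher number from compound 1 to compound 2 (0.33 log units; beyond the scatter), where 2-ethylphenyl gave the lower number and 4-nitrophenyl the limit. Returning to a phenyl bearing only methyl groups, 3,4-dimethylphenyl, is expected to move the number back toward that of compound 1, an expected step of an at least 2.0-fold lower number from compound 2 to compound 3 (0.30 log units; that floor lies within the scatter). Compound 3 is estimated at 25000 nM, between 10000 nM and 60000 nM.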

Compound 3, half-maximal inhibitory concentration: > 50000 nM
Compound 3 was reported as a limit; the forecaster's own chance of this, stated with the estimate: 30%; middle value at least 2.0-fold (0.30 log units) away from the limit.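

In this assay, the change from 2-ethylphenyl to 3,4-dimethylphenyl gives an at least 2.1-fold higher number from compound 1 to compound 3 (0.33 log units; beyond the scatter). A higher number at this position therefore does not go with 4-nitrophenyl alone, since a phenyl bearing only methyl groups shows it too. Compound 2 and compound 3 each stand at a limit and not at a number, so the step between them cannot be read: the limit of > 50000 nM in this assay, at which 2 of the 3 values shown sit.

Still open, going by these compounds, is whether a phenyl bearing an amine or a carboxylic acid, or a longer chain in place of the ethyl, would give a readable number in this assay.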